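Pyrazole series: phenyl against benzyl on the ring nitrogen

This account rests on a few compounds, and the source may have more. Where it says the series, first, only, none or still open, it means among the compounds named here.

Measured so far:
compound 1 `COc1ccc(Br)cc1-c1ccn(-c2ccccc2)n1` — > 200000 nM
compound 2 `COc1ccc(Br)cc1-c1ccn(Cc2ccccc2)n1` — > 200000 nM
compound 3 `CCCc1ccc(O)c(-c2ccn(-c3ccccc3)n2)c1` — 109000 nM

In a functional assay on BV-2 cells (Mus musculus) for inhibition, read by Griess assay, with a stated time of 24 h (a higher number here means a weaker inhibitor, a lower number a stronger inhibitor), compound 1 reaches only the upper limit of the assay, > 200000 nM, not a number. Compound 2 likewise sits at the limit, > 200000 nM. The change between them is benzyl in place of phenyl on an aromatic nitrogen, and the step that the two limits leave unreadable from compound 1 to compound 2 therefore cannot be read from these two limits. Among the measured compounds shown here, compound 3 is the one compound of the three with a number in this assay, 109000 nM, and that number is weak. How the core of compound 3 differs from the core of compound 1 is not broken down here.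

Compound 4 `CCCc1ccc(O)c(-c2ccn(Cc3ccccc3)n2)c1` is not yet measured. It differs from compound 3 by benzyl in place of phenyl on an aromatic nitrogen, the same kind of change as from compound 1 to compound 2, though around the place the ring atom in compound 3 bears a large group where in compound 1 it bears a group of 9 heavy atoms.

With the earlier step unreadable, no direction can be taken from it. The estimate for compound 4 rests only on compound 3 at 109000 nM: compound 4 is expected near that value, 130000 nM, between 40000 nM and 400000 nM, so that the expected step of a 1.2-fold higher number from compound 3 to compound 4 (0.08 log units; within the scatter) is small. A limit rather than a number is a real possibility because of the limit of > 200000 nM in this assay, at which 2 of the 3 values shown sit.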

Compound 4, half-maximal inhibitory concentration: 116000 nM
For compound 4 the middle estimate is 1.1-fold (0.05 log units) above the measured one, and the stated range covers the measured number.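

In this assay, benzyl in place of phenyl on an aromatic nitrogen gives a 1.1-fold higher number from compound 3 to compound 4 (0.03 log units; within the scatter), so on the core of compound 3 the two groups cannot be told apart in this read-out. The same change on the core of compound 1 cannot be read, because compound 1 and compound 2 each stand at a limit of the assay and not at a number: the limit of > 200000 nM in this assay, at which 2 of the 4 values shown sit. The change is therefore shown on one core only, and nothing here shows that it carries over from one core to the other, or that the result would hold on a core giving a stronger inhibitor, since compound 3 gives only 109000 nM.

On these data alone, whether phenethyl on the aromatic nitrogen, or a benzyl group carrying an amine or a carboxylic acid, would move the read-out beyond the scatter remains open. The core of compound 1 and the core of compound 3 also differ in more than one place, so the compounds shown leave open which of those differences, if any, separates a limit from a number.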